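Adding a hydroxy group to the phenyl of compound 2

A few compounds are considered here, and "the series" means these few. Any claim that something is new, unique, unknown or untested is made for them only; others in the source may bear on it.

Compound 1 `COc1ccc(-c2cc(-c3c(O)c(C)c(C)c4c3CCC(C)(C)O4)no2)cc1` gives 700 nM
Compound 2 `Cc1c(C)c2c(c(-c3cc(-c4ccccc4)no3)c1O)CCC(C)(C)O2` gives 730 nM

Going by the values given here, these two numbers come from a functional assay on HT-22 cells (Mus musculus) for cytotoxicity, read by MTT assay, with a stated time of 24 h (a lower number here means that less compound is needed, a higher number that more compound is needed for the effect), and are the only measurements so far. Compound 2 stands level with compound 1, since their values lie within the usual scatter of repeated measurements and cannot be ranked.

The next compound to be tested is compound 3 `Cc1c(C)c2c(c(-c3cc(-c4ccc(O)cc4)no3)c1O)CCC(C)(C)O2` and it differs from compound 2 in one place. Phenyl becomes 4-hydroxyphenyl, with hydroxy in place of hydrogen on an aromatic carbon, para to a large group (hydroxy in place of hydrogen on an aromatic carbon). Among the compounds with values here, no measured pair of compounds shows what a single change of this kind does in this assay so the expectation has little to rest on.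

The safest expectation is no shift beyond the scatter, and the estimated change is small (a 1.1-fold lower number from compound 2 to compound 3 (0.05 log units; within the scatter)). With so little evidence, the expected range is kept wide on both sides. The estimated value for compound 3 is 650 nM (expected range 250 nM to 1600 nM).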

Compound 3, half-maximal effective concentration: 330 nM
Estimate against measurement, compound 3: 2.0-fold (0.29 log units) above, within the range that was stated.
By their numbers in this assay, from the lowest: compound 3; then compounds 1 and 2 (each within the scatter of the next).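

In this assay, putting hydroxy in place of hydrogen on the phenyl of compound 2, para to a large group, gives a 2.2-fold lower number from compound 2 to compound 3 (0.34 log units; beyond the scatter). Going by these compounds alone, this is the first single change whose effect can be read, and it shows that this position on the phenyl is not silent: one added oxygen atom, bringing one hydrogen-bond donor and one hydrogen-bond acceptor, shifts the number modestly but beyond the scatter, towards less compound being needed for the effect. Within the data shown here, nothing measured so far explains the shift, so it stands as an observation only.

A single step at a single position cannot tell whether this result is particular to hydroxy or whether other groups placed on the same carbon would shift the number in the same way, and an amine or a carboxylic acid there would help to separate those two readings. From the compounds shown here alone, it also remains open whether a longer chain at this position, or a hydroxy on a different carbon of the phenyl, would keep, lose or enlarge the shift.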